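A Methoxy Group Added to the Outer Ring

The source may report more compounds than this note shows. Statements on the series, on what has been measured and on what is new or still open speak of the compounds shown alone.

Of the compounds shown here, two have been measured in an assay on isolated protein for displacement of a labelled ligand from melanin-concentrating hormone receptor 1 (Rattus norvegicus); on this read-out lower numbers stand for stronger inhibition and higher numbers for weaker inhibition. Compound 1 `Cc1ccc(Oc2cccc(CN3CCC(c4cccc(NC(=O)C(C)C)c4)CC3)c2)cc1` gives 31 nM there, and compound 2 `CC(C)C(=O)Nc1cccc(C2CCN(Cc3ccc(Oc4ccccc4)cc3)CC2)c1` gives 10 nM, the lower of the two numbers and a gap beyond the usual scatter. Compound 3 `COc1ccc(Oc2ccc(CN3CCC(c4cccc(NC(=O)C(C)C)c4)CC3)cc2)cc1` is not yet measured; it differs from compound 2 by methoxy in place of hydrogen on an aromatic carbon, placed on an aromatic carbon of a six-membered aromatic ring of carbon only. For the measured compounds named here, no measured pair shows such a change, so the step of a 1.2-fold higher number from compound 2 to compound 3 (0.08 log units; within the scatter) is expected to stay within the scatter, in either direction. Compound 3 is estimated at 12 nM, between 4 nM and 40 nM.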

Compound 3, inhibition constant: 35 nM
The estimate for compound 3 lay 2.9-fold (0.46 log units) below the measured number, within the range that was stated.
By their numbers in this assay, from the lowest: compound 2; then compounds 1 and 3 (each within the scatter of the next).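

The change from phenoxy to 4-methoxyphenoxy in this assay is not silent: it brings a 3.5-fold higher number from compound 2 to compound 3 (0.54 log units; beyond the scatter) and so gives weaker inhibition. For the compounds shown here, this is the first step read at this place, para to a large group, and it shows that the number responds to what sits there. No measurement shown gives a reason for this step.

Going by these compounds, it remains open whether fluorine, hydroxyl or an amine at this place would raise the number as methoxy does. Methoxy on another carbon of this ring also remains open.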